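This account rests on a few compounds, and the source may have more. Where it says the series, first, only, none or still open, it means among the compounds named here.

Three compounds have measured values.
Compound 1 `CCCCCc1ccc(C#Cc2c(-c3ccc(CCCCC)cc3)oc3nc(=O)n(Cc4cn(-c5ccc(Cl)cc5)nn4)cc23)cc1`: > 100000 nM, a limit of the assay.
Compound 2 `O=c1nc2oc(CCCCl)cc2cn1Cc1cn(-c2ccccc2F)nn1`: 79800 nM.
Compound 3 `CCCCCCC#Cc1c(CCCCCC)oc2nc(=O)n(Cc3cn(-c4ccc(Cl)cc4)nn3)cc12`: > 100000 nM, a limit of the assay.

Going by the values given here, in a functional assay on HepG2 cells (Homo sapiens) for antiproliferative activity, read by MTT assay, with a stated time of 72 h (a higher number here means a weaker inhibitor, a lower number a stronger inhibitor), compound 2 gives 79800 nM, the only number that is not a limit. For compound 1 the reading is a limit, > 100000 nM. For compound 3 the reading is likewise a limit, > 100000 nM. Compound 2 therefore stands alone with a number, against (the limit of > 100000 nM in this assay, at which 2 of the 3 values shown sit). Compound 4 `O=c1nc2oc(CCCCl)cc2cn1Cc1cn(Cc2ccccc2)nn1` differs from compound 2 in one place: benzyl in place of 2-fluorophenyl on an aromatic nitrogen. Among the compounds with values here, no measured pair tests this change, so no step size can be read from the data. The expected step of a 1.0-fold higher number from compound 2 to compound 4 (0.00 log units; within the scatter) is judged to stay within the scatter, in no particular direction. Compound 4 is expected at 80000 nM, with a range from 30000 nM to 200000 nM.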

Compound 4, half-maximal inhibitory concentration: 27600 nM
The estimate for compound 4 lay 2.9-fold (0.46 log units) above the measured number, outside the stated range (below it).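

In this assay, benzyl in place of 2-fluorophenyl on an aromatic nitrogen gives a 2.9-fold lower number from compound 2 to compound 4 (0.46 log units; beyond the scatter), so the group at this position does move the number. Both groups hold the same count of heavy atoms and one six-membered aromatic ring of carbon only, so those counts alone do not set the number.

Going by these compounds, this single pair cannot separate the loss of fluorine from the added carbon, and an amine or a longer chain at this position remains open. No steps involving compound 1 or compound 3 can be read: the limit of > 100000 nM in this assay, at which 2 of the 4 values shown sit.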